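A few compounds are considered here, and "the series" means these few. Any claim that something is new, unique, unknown or untested is made for them only; others in the source may bear on it.

Measured compounds:
Compound 1 `O=C1O[C@H]([C@@H](O)Cn2cc(-c3cccc(O)c3)nn2)C(OCc2ccccc2)=C1OCc1ccccc1`: 51800 nM in a functional assay on MCF7 cells (Homo sapiens) for antiproliferative activity, read by MTT assay, with a stated time of 72 h; a lower number here means a stronger inhibitor, a higher number a weaker inhibitor
Compound 2 `CC(C)(C)OC(=O)N1CCN(C(=S)SCc2cn(C[C@H](O)[C@H]3OC(=O)C(OCc4ccccc4)=C3OCc3ccccc3)nn2)CC1`: > 100000 nM, a limit of the assay and not a number
Compound 3 `COc1ccccc1-c1cn(C/C=C2\OC(=O)C(OCc3ccccc3)=C2OCc2ccccc2)nn1`: > 100000 nM, a limit of the assay and not a number

All three compounds share the same core. In this assay, among the compounds with values here, compound 1 gives 51800 nM, the only real number among the three. Compound 2 gives > 100000 nM, which is a limit of the assay. Compound 3 gives > 100000 nM, again a limit of the assay. Within the data shown here, compound 1 therefore stands alone as the one compound with a measured number, while the other two sit at the limit of > 100000 nM in this assay, at which 2 of the 3 values shown sit. Among the measured compounds shown here, no pair of measured compounds differs in just one place, so the size of any single structural change cannot be read from these data.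

Compound 4 `O=C1O[C@H]([C@@H](O)Cn2cc(C3CC3)nn2)C(OCc2ccccc2)=C1OCc1ccccc1` differs from compound 1 in one place: cyclopropyl in place of 3-hydroxyphenyl on an aromatic carbon. Because compound 1 is itself a weak inhibitor at 51800 nM, the expectation for this change is either a step toward weaker inhibition that is beyond the scatter or no step beyond the scatter, rather than a gain. Compound 2 and compound 3 give nothing more than a limit of the assay, so they add no measured number to weigh against this. Compound 4 is expected at about 80000 nM, with a range from 30000 nM to 200000 nM. That estimate means an expected step of a 1.5-fold higher number from compound 1 to compound 4 (0.19 log units; within the scatter).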

Compound 4, half-maximal inhibitory concentration: 25900 nM
Beside the measured number, compound 4's estimate is 3.1-fold (0.49 log units) above it, outside the stated range (below it).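

In this assay, within the data shown here, the step of a 2.0-fold lower number from compound 1 to compound 4 (0.30 log units; within the scatter) gives the first comparison in this set of compounds that changes one place only: the group on the aromatic carbon of the five-membered aromatic ring with 3 nitrogen. The change replaces a six-membered aromatic ring of carbon with a three-membered non-aromatic one, and the hydrogen-bond donor and acceptor counted on 3-hydroxyphenyl are absent from cyclopropyl. For this one pair, then, neither the aromatic ring nor the hydroxyl group is needed to keep the number within the scatter, although a single pair cannot show how the position behaves in general.

The compounds shown leave open whether another group at this position, such as an amine, a carboxylic acid or a longer alkyl chain, would move the number in this assay beyond the scatter. Steps to compound 2 and compound 3 cannot be read, as each differs from compound 1 and compound 4 in more than one place and each gives only a limit of the assay and not a number: the limit of > 100000 nM in this assay, at which 2 of the 4 values shown sit.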